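From methyl to piperidin-1-yl at the assay limit

This account rests on a few compounds, and the source may have more. Where it says the series, first, only, none or still open, it means among the compounds named here.

In an ADME assay on MRC5 cells (Homo sapiens) for cytotoxicity, read by neutral red uptake (a higher number here means that more compound is tolerated, a lower number that less compound is tolerated), compound 1 (`O=c1[nH]c(SCc2ccccc2Cl)nc2ccccc12`) gives > 65000 nM, which is a limit and not a number. Compound 2 (`O=c1[nH]c(SCc2cc([N+](=O)[O-])cc([N+](=O)[O-])c2)nc2ccc(Cl)cc12`) gives > 64000 nM in this assay, also a limit. Compound 3 (`Cc1ccc2nc(SCc3cc([N+](=O)[O-])cc([N+](=O)[O-])c3)[nH]c(=O)c2c1`) gives > 64000 nM in this assay, again a limit. Compound 3 therefore stands at the limit of > 64000 nM in this assay, at which 2 of the 3 values shown sit, and no number is available for it.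

The next compound is compound 4 (`O=c1[nH]c(SCc2cc([N+](=O)[O-])cc([N+](=O)[O-])c2)nc2ccc(N3CCCCC3)cc12`), which carries piperidin-1-yl in place of methyl on an aromatic carbon. The change is piperidin-1-yl in place of methyl on an aromatic carbon.

Going by the values given here, the one measured step that bears on this change is a step that the two limits leave unreadable from compound 2 to compound 3, with methyl in place of chloro on an aromatic carbon. It offers no size to carry over, and piperidin-1-yl has no measured value in this set. The expectation starts from compound 3, whose > 64000 nM is a limit. A modest step toward less compound tolerated is expected in this assay, though another limit remains quite likely. The estimated move is an at least 1.2-fold lower number from compound 3 to compound 4 (0.10 log units; that floor lies within the scatter). For compound 4 the estimated half-maximal cytotoxic concentration is 50000 nM, with an expected range from 15000 nM to 64000 nM.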

Compound 4, half-maximal cytotoxic concentration: > 64000 nM
Compound 4 ended at the assay's limit (the forecaster's own chance of this, stated with the estimate: 60%); middle value at least 1.2-fold (0.10 log units) away from the limit.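

In this assay compound 4 gives > 64000 nM, again a limit. The steps from compound 2 to compound 4 and from compound 3 to compound 4 cannot be read: all three values are limits. Whether piperidin-1-yl, methyl or chloro on that aromatic carbon shifts the tolerated concentration at all stays open, with no compound shown giving a number.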